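Lipophilicity of a methoxy-substituted pyridone analogue

The compounds below may be only part of what the source reports. "The series", "measured", "known", "first", "only" and "open" are said of these compounds alone.

Of the compounds shown here, three sharing one core have been measured in a physicochemical assay for lipophilicity, using the shake flask method, measured as octanol-water partition, at pH 7.4; a higher number here means a more lipophilic compound, a lower number a more polar compound. Compound 1 `CN(C)C(=O)CN1CCC(c2cc3c(-c4ccc(=O)n(C)c4)ccnc3[nH]2)CC1` gives 1.1. Compound 2 `COc1cc(F)ccc1-c1ccnc2[nH]c(C3CCN(CC(=O)N(C)C)CC3)cc12` gives 2.9. Compound 3 `CCn1cc(-c2ccnc3[nH]c(C4CCN(CC(=O)N(C)C)CC4)cc23)ccc1=O` gives 1.2, which places compound 3 second highest of the three: its nearest neighbour is compound 1, and the two lie within the scatter of each other, while compound 2 sits far above it, as the step of a number 1.70 log units lower from compound 2 to compound 3 (beyond the scatter) shows.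

The unmeasured compound 4 `COc1cc(=O)n(C)cc1-c1ccnc2[nH]c(C3CCN(CC(=O)N(C)C)CC3)cc12` differs from compound 3 in one place: a group of 10 heavy atoms (7 carbon, 1 nitrogen, 2 oxygen; one six-membered aromatic ring with 1 hetero atom) in place of a group of 9 heavy atoms (7 carbon, 1 nitrogen, 1 oxygen; one six-membered aromatic ring with 1 hetero atom), on an aromatic carbon.

The step that bears most directly on this change is a number 0.10 log units higher from compound 1 to compound 3 (within the scatter), which shows that swapping methyl and ethyl on the chain carbon bound to the aromatic nitrogen leaves the reading essentially unchanged. The large steps of a number 1.80 log units higher from compound 1 to compound 2 (beyond the scatter) and a number 1.70 log units lower from compound 2 to compound 3 (beyond the scatter) concern exchanging the whole six-membered ring for a carbon-only ring and so do not describe the present change, which keeps the ring with one hetero atom and adds a single oxygen. Going by the values given here, no measured step shows what that added oxygen does here.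

Compound 4 is therefore expected to give a reading close to that of compound 3, with a step of about no change at the digits printed from compound 3 to compound 4 (within the scatter), estimated at 1.2 within a range of 0.8 to 1.6.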

Compound 4, distribution coefficient: 0.7
Estimate against measurement, compound 4: 0.50 log units above; measured number outside the range, below it.
By their numbers in this assay, from the lowest: compound 4; then compounds 1 and 3 (each within the scatter of the next); then compound 2.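

In this assay, the step of a number 0.40 log units lower from compound 1 to compound 4 (beyond the scatter) shows that methoxy in place of hydrogen on an aromatic carbon of the six-membered ring with 1 hetero atom does shift the reading, and the step of a number 0.50 log units lower from compound 3 to compound 4 (beyond the scatter) points the same way, so the added oxygen is not neutral here, as the earlier change of methyl to ethyl on that ring was. The step of a number 2.20 log units lower from compound 2 to compound 4 (beyond the scatter) links two compounds that both carry a methoxy, so methoxy alone does not fix the reading, and the ring that holds it matters as well. Nothing measured here explains why the reading moves in this way.

The compounds shown leave open whether another group on that same ring carbon, such as an amine, a chlorine atom or the longer ethoxy, would shift the reading in the same direction or by a similar amount. They also leave open how methoxy behaves on that ring when the ring nitrogen carries ethyl instead of methyl.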